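Mirror Image of Compound 2 at the Vanilloid Receptor

The source may report more compounds than this note shows. Statements on the series, on what has been measured and on what is new or still open speak of the compounds shown alone.

For the measured compounds named here, in a functional assay on CHO cells for antagonist activity at transient receptor potential cation channel subfamily V member 1 (Rattus norvegicus) (on this read-out lower numbers stand for stronger inhibition and higher numbers for weaker inhibition), compound 2 `C[C@@H](C(=O)NC[C@H](COC(=O)C(C)(C)C)Cc1ccccc1)c1ccc(NS(C)(=O)=O)c(F)c1` gives 98 nM, the higher of the two numbers measured so far; compound 1 `C[C@H](C(=O)NC[C@H](COC(=O)C(C)(C)C)Cc1ccccc1)c1ccc(NS(C)(=O)=O)c(F)c1` gives 8.56 nM. Compound 3 `C[C@H](C(=O)NC[C@@H](COC(=O)C(C)(C)C)Cc1ccccc1)c1ccc(NS(C)(=O)=O)c(F)c1` is the mirror image of compound 2: the two compounds have the same atoms and bonds and differ only in configuration as drawn: 2 of 2 stereo elements differ (all stereocentres are inverted: mirror images); a stereocentre at a saturated chain carbon is drawn R in compound 2 and S in compound 3; a stereocentre at a saturated chain carbon is drawn R in compound 2 and S in compound 3. Going by the values given here, one measured step bears on this change: an 11-fold higher number from compound 1 to compound 2 (1.06 log units; beyond the scatter), a shift that rests on (the fact that compounds 1 and 2 differ only in the configuration as drawn). Compound 3 carries the configuration of compound 1 at that same centre, while the second centre has no measured comparison. A step of a 4.9-fold lower number from compound 2 to compound 3 (0.69 log units; beyond the scatter) is therefore expected. Compound 3 is estimated at 20 nM, with a range from 5 nM to 100 nM.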

Compound 3, inhibition constant: 10 nM
Estimate against measurement, compound 3: 2.0-fold (0.30 log units) above, within the range that was stated.
By their numbers in this assay, from the lowest: compounds 1 and 3 (each within the scatter of the next); then compound 2.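

The stereocentre that had no earlier comparison now has one: in this assay, a 1.2-fold higher number from compound 1 to compound 3 (0.07 log units; within the scatter), so inverting it alone has no effect that can be told from the scatter in this pair. For the compounds shown here, the full mirror-image change, a 9.8-fold lower number from compound 2 to compound 3 (0.99 log units; beyond the scatter), thus appears to follow the other centre, the one at which compound 1 and compound 2 differ. Only spatial arrangement separates these compounds: the fact that compounds 2 and 3 differ only in the configuration as drawn

From the compounds shown here alone, whether the first centre stays this tolerant when the ester gives way to a carboxylic acid or an amine remains open.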